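This account rests on a few compounds, and the source may have more. Where it says the series, first, only, none or still open, it means among the compounds named here.

Measured so far:
- compound 1, `O=[N+]([O-])c1cc(Sc2nnnn2C2CCCCC2)cc([N+](=O)[O-])c1`: 153000 nM
- compound 2, `O=[N+]([O-])c1cc(-c2nnn(Cc3cccc(Br)c3)n2)cc([N+](=O)[O-])c1`: 29000 nM

Both numbers come from an ADME assay on CHO-K1 cells (Cricetulus griseus) for cytotoxicity, read by MTT assay, with a stated time of 24 h; a higher number here means a weaker inhibitor, a lower number a stronger inhibitor. Among the measured compounds shown here, compound 2 stands at the lower of the two, and the gap to compound 1, the only other measured compound, lies beyond the usual scatter of this assay, so compound 2 is the stronger inhibitor of the pair. For the measured compounds named here, the two compounds differ in several places at once, so no single structural step between them can be read off.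

Compound 3, `O=[N+]([O-])c1cc(-c2nnn(Cc3ccc(Cl)c(Cl)c3)n2)cc([N+](=O)[O-])c1`, has not yet been measured. It differs from compound 2 in one place only: 3,4-dichlorophenyl in place of 3-bromophenyl on a saturated chain carbon bound to an aromatic nitrogen. Going by the values given here, no measured pair shows this kind of change, so there is no directly comparable step to lean on. One halogenated phenyl group is swapped for another on the same chain carbon, and the rest of the molecule, including the shared core, is unchanged. The expected step of a 1.2-fold lower number from compound 2 to compound 3 (0.06 log units; within the scatter) is therefore small, with no clear direction beyond the scatter. Compound 3 is estimated at 25000 nM, with a range from 8000 nM to 80000 nM.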

Compound 3, half-maximal inhibitory concentration: 37000 nM
Compound 3: middle estimate off by 1.5-fold (0.17 log units), on the low side, within the range that was stated.
By their numbers in this assay, from the lowest: compounds 2 and 3 (each within the scatter of the next); then compound 1.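

In this assay, putting 3,4-dichlorophenyl in place of 3-bromophenyl on a saturated chain carbon bound to an aromatic nitrogen gives a 1.3-fold higher number from compound 2 to compound 3 (0.11 log units; within the scatter). Among the compounds shown here, this is the first comparison here of two compounds that differ in one place only, and it shows that compound 2 and compound 3 cannot be told apart in this test. At this position, then, one halogenated phenyl group can take the place of another, a bromine giving way to two chlorines, without a readable shift in the number, and nothing measured here speaks to why the two values sit so close.

As far as these compounds go, both groups are halogen-bearing phenyl rings, so it remains open what happens at this position with something that is not a phenyl ring at all, such as an amine, a carboxylic acid or a longer chain. A plain phenyl ring, or one carrying a methoxy group, would show whether any halogen on the ring matters for the number in this assay.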